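Plasma stability of hydroxamic acids with a triazole thioether core

This account rests on a few compounds, and the source may have more. Where it says the series, first, only, none or still open, it means among the compounds named here.

The series is examined in an ADME assay on a cell-free system (plasma, Homo sapiens) for metabolic stability, read by LC-MS, with a stated time of 4 h, tested at 100 uM; a higher number here means that more of the compound is left, a lower number that less of the compound is left. Compound 1 `Cc1cc(-c2nnc(Sc3c(F)cc(C(=O)NO)cc3F)n2C)nn1C` gives 92% and stands lowest of the three numbers, though its nearest neighbour, compound 2 `O=C(NO)c1cc(F)c(Cc2nnc(-c3ccncc3)s2)c(F)c1` with 93%, and its furthest, compound 3 `Cn1c(Sc2ccc(C(=O)NO)cc2)nnc1-c1cccs1` with 100%, both lie within the scatter of it. Compound 4 `Cn1c(Sc2c(F)cc(C(=O)NO)cc2F)nnc1-c1cccs1` has not yet been measured; it differs from compound 1 by thiophen-2-yl in place of 1,5-dimethyl-1H-pyrazol-3-yl on an aromatic carbon. Going by the values given here, no measured pair shows this change on its own. Since every measured value sits near the top of the range, the author expects the step of a number 3 percentage points higher from compound 1 to compound 4 (within the scatter) to remain within the scatter, leaning upward because compound 3 gives 100%. Compound 4 is therefore estimated at 95%, within 85% to 100%.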

Compound 4, percent of the compound remaining: 99%
Compound 4: middle estimate off by 4 percentage points, on the low side, within the range that was stated.
By their numbers in this assay, from the lowest: compounds 1, 2, 4 and 3 (each within the scatter of the next).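

In this assay, going by these compounds alone, thiophen-2-yl in place of 1,5-dimethyl-1H-pyrazol-3-yl on an aromatic carbon gives a number 7 percentage points higher from compound 1 to compound 4 (within the scatter) and so provides the first reading of this change on its own. At this place, between two ring nitrogen atoms, the two five-membered aromatic rings cannot be told apart by this read-out.

On these data alone, whether an amine or a carboxylic acid at the same place would give a step beyond the scatter remains open. Nothing available offers a reason for the size of this step.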